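Swapping the aryl group on the sulfonyl sulfur

This account rests on a few compounds, and the source may have more. Where it says the series, first, only, none or still open, it means among the compounds named here.

Measured compounds:
compound 1 `Cc1cc(Nc2ccc(F)cc2)nc(Nc2ccc(NS(=O)(=O)c3ccc(C(F)(F)F)cc3)cc2)n1` — 17500 nM
compound 2 `Cc1cc(Nc2ccc(F)cc2)nc(Nc2ccc(NS(=O)(=O)c3ccccc3OC(F)(F)F)cc2)n1` — 23800 nM

Of the compounds shown here, two from this series have been tested in a functional assay on MDA-MB-231 cells (Homo sapiens) for antiproliferative activity, read by MTT assay; a higher number here means a weaker inhibitor, a lower number a stronger inhibitor. In that assay compound 1 gives 17500 nM, and compound 2 gives 23800 nM. Going by the values given here, compound 2 thus holds the higher of the two numbers, but its only neighbour is compound 1, and the step between them is small: a 1.4-fold higher number from compound 1 to compound 2 (0.13 log units; within the scatter). On the numbers shown, the two compounds cannot be told apart.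

Compound 3 `COc1cc(C)cc(Cl)c1S(=O)(=O)Nc1ccc(Nc2nc(C)cc(Nc3ccc(F)cc3)n2)cc1` is the next member, not yet measured. It differs from compound 2 in one place: 2-chloro-6-methoxy-4-methylphenyl in place of 2-(trifluoromethoxy)phenyl on a sulfonyl sulfur. Among the compounds with values here, the one measured step that bears on this change is the one from compound 1 to compound 2, which also exchanged the aryl group on the sulfonyl sulfur and gave a 1.4-fold higher number from compound 1 to compound 2 (0.13 log units; within the scatter). Within the data shown here, with that as the only guide, no step beyond the scatter is expected for compound 3 in this assay, and the expected step is a 1.1-fold lower number from compound 2 to compound 3 (0.05 log units; within the scatter). For compound 3 the estimate in this assay is 21000 nM, expected to fall between 7000 nM and 60000 nM.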

Compound 3, half-maximal inhibitory concentration: > 50000 nM
Compound 3 ended at the assay's limit; the forecaster's own chance of this, stated with the estimate: 10%; at least 2.3-fold (0.37 log units) between middle value and limit.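

In this assay, the aryl group on the sulfonyl sulfur turns out not to be freely exchangeable. Putting 2-chloro-6-methoxy-4-methylphenyl in place of 2-(trifluoromethoxy)phenyl gave an at least 2.1-fold higher number from compound 2 to compound 3 (0.32 log units; beyond the scatter), and the same group in place of 4-(trifluoromethyl)phenyl gave an at least 2.8-fold higher number from compound 1 to compound 3 (0.45 log units; beyond the scatter), so this position can move the read-out beyond the scatter, which the earlier pair of compounds, with their step inside it, did not show. The value of compound 3 is a limit of the assay and not a number, so both steps give only a lower bound on the true size: the limit of > 50000 nM in this assay, at which 1 of the 3 values shown sits.

The compounds shown change the chlorine, the methoxy and the methyl together, so they do not tell whether one of these substituents alone accounts for the step or whether it takes the combination. They also leave open how the series would respond to a different kind of group on that aryl ring, such as an amine or a carboxylic acid, and whether any group at this sulfonyl sulfur could give a lower number than compound 1 and compound 2.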